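Compound 1 to compound 3: one side chain exchanged

A few compounds are considered here, and "the series" means these few. Any claim that something is new, unique, unknown or untested is made for them only; others in the source may bear on it.

Values so far in an in vitro ADME assay on microsomes from liver (Homo sapiens) for metabolic stability, in the presence of a further agent that is not named here (on this read-out higher numbers stand for fast clearance and lower numbers for slow clearance), are:
- Compound 1 `COc1ccc(C(F)(F)F)cc1Cn1c(C(=O)NCC2(CO)CC2)cc2cc(C#N)ccc21` gives 7 mL.min-1.g-1
- Compound 2 `COc1ccc(C(C)(C)C)cc1Cn1c(C(=O)NCC2(CO)CC2)cc2cc(C#N)ccc21` gives < 6 mL.min-1.g-1 (a limit of the assay)

Within the data shown here, compound 1 holds the only actual number in this small set, at 7 mL.min-1.g-1. Compound 2 is reported as < 6 mL.min-1.g-1, which is a limit and not a number.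

Compound 3 `COc1ccc(C(F)(F)F)cc1Cn1c(C(=O)NCCC2(O)CCC2)cc2cc(C#N)ccc21` has not yet been measured. Its difference from compound 1 is (1-hydroxycyclobutyl)methyl in place of 1-(hydroxymethyl)cyclopropyl on a saturated chain carbon bound to an amide-type nitrogen, on a saturated chain carbon bound to an amide-type nitrogen.

Among the measured compounds shown here, the only measured step is an at least 1.1-fold lower number from compound 1 to compound 2 (0.06 log units; that floor lies within the scatter). It puts tert-butyl in place of trifluoromethyl on an aromatic carbon, so it leaves this side chain untouched, and its floor lies within the scatter. For the measured compounds named here, no measured step changes the side chain itself. The expectation therefore rests on compound 1 with 7 mL.min-1.g-1, and no step beyond the scatter is expected in this assay, in either direction. The estimated step is a 1.1-fold higher number from compound 1 to compound 3 (0.06 log units; within the scatter). For compound 3 the expected value is 8 mL.min-1.g-1, with an estimated range from 4 mL.min-1.g-1 to 16 mL.min-1.g-1.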

Compound 3, intrinsic clearance in microsomes: < 6 mL.min-1.g-1
Compound 3 was reported as a limit (the forecaster's own chance of this, stated with the estimate: 30%); middle value at least 1.3-fold (0.12 log units) from the limit.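

Among these compounds, compounds 1 and 2 carry the same side chain, so this pair gives the only view of a change on a saturated chain carbon bound to an amide-type nitrogen. In this assay, putting (1-hydroxycyclobutyl)methyl in place of 1-(hydroxymethyl)cyclopropyl gives an at least 1.1-fold lower number from compound 1 to compound 3 (0.06 log units; that floor lies within the scatter). Compound 3 is reported as a limit and not a number, so the floor of this step is all that can be read, and its true size stays unknown because of that limit: the limit of < 6 mL.min-1.g-1 in this assay, at which 2 of the 3 values shown sit.

The compounds shown leave open whether this place would keep clearance in the same range if the side chain carried an amine or a carboxylic acid instead of the hydroxy group, or if a longer chain stood there. They also leave open how (1-hydroxycyclobutyl)methyl behaves together with tert-butyl on the aromatic carbon, and how far below the limit any of these side chains truly lies in this assay.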